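Replacing aminomethyl with methanesulfonamido in compound 1

This account rests on a few compounds, and the source may have more. Where it says the series, first, only, none or still open, it means among the compounds named here.

Of the compounds shown here, three have been measured in a functional assay, with a stated time of 15 min; a lower number here means that less compound is needed, a higher number that more compound is needed for the effect. Compound 1 (`NCc1ccc(O)c2ccccc12`) gives 260000 nM, the middle of the three numbers. Compound 3 (`Nc1ccc(CO)c2ccccc12`) stands higher at 1000000 nM, and compound 2 (`Nc1ccc(OCc2ccccc2)c2ccccc12`) stands lower at 7000 nM. Both gaps from compound 1 lie beyond the scatter.

The unmeasured compound 4 (`CS(=O)(=O)Nc1ccc(O)c2ccccc12`) carries methanesulfonamido in place of aminomethyl on an aromatic carbon, para to a hydroxy group: methanesulfonamido in place of aminomethyl on an aromatic carbon. Among the compounds with values here, no measured pair shows a change of this kind, so any forecast is loose. Compound 2, with 7000 nM, shows that much lower numbers are reachable on the shared core, while compound 3, with 1000000 nM, shows that higher ones are too. A moderate move towards a lower number is expected, an estimated 5.2-fold lower number from compound 1 to compound 4 (0.72 log units; beyond the scatter), though a step of this size remains uncertain. For compound 4 the estimated value in this assay is 50000 nM, with an expected range from 5000 nM to 400000 nM.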

Compound 4, half-maximal effective concentration: 18000 nM
Estimate against measurement, compound 4: 2.8-fold (0.44 log units) above; measured number inside the range.
By their numbers in this assay, from the lowest: compound 2; then compound 4; then compound 1; then compound 3.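

In this assay the exchange of aminomethyl for methanesulfonamido on this aromatic carbon, para to a hydroxy group, gives a 14-fold lower number from compound 1 to compound 4 (1.16 log units; beyond the scatter) and this large step lies beyond the scatter. Within the data shown here, it is the first step that can be read at a single place, and it shows that the number responds strongly to the group on this carbon while the hydroxy group and the rest of the shared core stay the same. Nothing measured on these compounds explains the step.

The compounds shown leave open whether the gain needs the whole methanesulfonamido group, since neither an acetamido group nor a longer ethanesulfonamido group appears at this place. They also leave open whether the same exchange would give a step of similar size with a group other than hydroxy on the ring.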